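Permeability notes: cyclopropylmethoxy to trifluoropropoxy on the shared core

This account rests on a few compounds, and the source may have more. Where it says the series, first, only, none or still open, it means among the compounds named here.

The series is followed in an ADME assay for permeability, using PAMPA, in phosphate buffer, with a stated time of 18 h, at pH 7.4; a lower number here means that the compound crosses the layer more slowly, a higher number that the compound crosses the layer faster. Compound 1 `N#Cc1ccccc1-c1cc(-c2cc(Cl)cc(OCCC(F)(F)F)c2)c(=O)n(-c2cccnc2)c1` gives 4 10^-6 cm/s in this assay. Compound 2 `O=c1[nH]cc(-c2cc(-c3cc(Cl)cc(OCc4ocnc4C(F)(F)F)c3)c(=O)n(-c3cccnc3)c2)c(=O)[nH]1` gives 0.57 10^-6 cm/s. Compound 3 `Cn1cc(-c2cc(-c3cc(Cl)cc(OCC4CC4)c3)c(=O)n(-c3cccnc3)c2)c(=O)[nH]c1=O` gives 3.25 10^-6 cm/s. Of these three numbers, compound 3 holds the second highest; its nearest neighbour is compound 1, whose number is higher by an amount within the usual scatter, so no order between compound 1 and compound 3 can be read from this assay. The furthest is compound 2, whose number is lower by an amount beyond the scatter.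

Compound 4 `Cn1cc(-c2cc(-c3cc(Cl)cc(OCCC(F)(F)F)c3)c(=O)n(-c3cccnc3)c2)c(=O)[nH]c1=O` has not yet been measured. It differs from compound 3 in one place: 2,2,2-trifluoroethyl in place of cyclopropyl on a saturated chain carbon bound to an oxygen on an aromatic ring. Among the measured compounds shown here, no measured pair isolates this same change, so nothing about its size is known directly; compound 1 carries the 3,3,3-trifluoropropoxy group of compound 4 but differs from compound 3 elsewhere as well, and its value and that of compound 3 lie within the scatter of one another.

Compound 4 is therefore expected to sit close to compound 3 in this assay, with a step of a 1.0-fold lower number from compound 3 to compound 4 (0.01 log units; within the scatter) that is expected to remain within the scatter. The estimate for compound 4 is 3.2 10^-6 cm/s, with a range from 1.6 10^-6 cm/s to 6.4 10^-6 cm/s.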

Compound 4, apparent permeability: 2.26 10^-6 cm/s
Estimate against measurement, compound 4: 1.4-fold (0.15 log units) above, and the stated range covers the measured number.
By their numbers in this assay, from the lowest: compound 2; then compounds 4, 3 and 1 (each within the scatter of the next).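

Among the compounds shown here, the pair of compound 3 and compound 4 is the first to isolate the change from cyclopropylmethoxy to 3,3,3-trifluoropropoxy, and in this assay it gives a 1.4-fold lower number from compound 3 to compound 4 (0.16 log units; within the scatter), so this exchange at the saturated chain carbon bound to an oxygen on an aromatic ring shows no resolvable effect on the read-out. With the 3,3,3-trifluoropropoxy group held constant, the exchange of the group on the aromatic carbon of the shared core gives a 1.8-fold lower number from compound 1 to compound 4 (0.25 log units; within the scatter), so this second position also shows no resolvable effect in this pair. Nothing further measured on these compounds bears on either step.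

The compounds shown leave open how an amine, a carboxylic acid or a longer chain in this position would read in this assay, and whether any change here can produce a step beyond the scatter. Also open is what lies behind the number of compound 2, 0.57 10^-6 cm/s; no pair shown links it to another compound by a single difference.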